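The source may hold more compounds than are shown below. What is called first, only, known or untested is meant among the compounds shown, and "the series" means these compounds.

For the measured compounds named here, compound 2 `O=c1c2ccccc2[se]n1-c1nnc(-c2ccccc2Br)s1` sits at the top of the two numbers so far: in a functional assay on MCF7 cells (Homo sapiens) for antiproliferative activity, read by CCK-8 assay, with a stated time of 48 h (on this read-out higher numbers stand for weaker inhibition and lower numbers for stronger inhibition), compound 2 gives 59400 nM. Going by the values given here, its only neighbour is compound 1 `O=c1c2ccccc2[se]n1-c1nnc(-c2ccccc2Cl)s1`, which in this assay gives 4430 nM, and the single step between them, a 13-fold higher number from compound 1 to compound 2 (1.13 log units; beyond the scatter), is large and beyond the scatter. Compound 3 `O=c1c2ccccc2[se]n1-c1nnc(-c2ccccc2[N+](=O)[O-])s1` is reached from compound 2 by a further change at the same place: nitro in place of bromo on an aromatic carbon. Among the compounds with values here, the step from compound 1 to compound 2 is the only one that bears on this move, and it shows that exchanging one group at this carbon can shift the number by a wide margin; no measured step involves nitro, so the direction of the new step is open. Because compound 2 gives 59400 nM, the highest number seen, the number for compound 3 is expected to come out somewhat lower, a step of a 4.0-fold lower number from compound 2 to compound 3 (0.60 log units; beyond the scatter), with wide uncertainty. Compound 3 is therefore estimated at 15000 nM, with a range of 2500 nM to 90000 nM.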

Compound 3, half-maximal inhibitory concentration: 31200 nM
Beside the measured number, compound 3's estimate is 2.1-fold (0.32 log units) below it; low and high end bracket the measured number.
By their numbers in this assay, from the lowest: compound 1; then compounds 3 and 2 (each within the scatter of the next).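

Within this assay the exchange of bromo for nitro on this aromatic carbon gives a 1.9-fold lower number from compound 2 to compound 3 (0.28 log units; within the scatter) and so, despite the larger nitro group with its hydrogen-bond acceptors, this change leaves the number within the scatter. The wide shift seen earlier is thus not a feature of every exchange at this carbon: the exchange of chloro for nitro gives a 7.0-fold higher number from compound 1 to compound 3 (0.85 log units; beyond the scatter) and compound 1 alone stands apart, with the lowest number of the three, beyond the scatter from both others. Nothing at hand accounts for this separation of chloro from bromo and nitro.

Whether chloro is a lone case at this carbon stays open, since the compounds shown give no reading for fluoro, methyl or methoxy. From the compounds shown here alone, how an amine or a carboxylic acid here would compare with compound 1 is equally open.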